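The compounds below may be only part of what the source reports. "The series", "measured", "known", "first", "only" and "open" are said of these compounds alone.

Compound 2 `CC(=O)c1ccc2c(c1)/C(=C/c1cccc(OCc3cn(Cc4ccccc4)nn3)c1)C(=O)N2` carries an acetyl group on an aromatic carbon of the shared core, with a benzyl-substituted triazole ether on the pendant ring. In a functional assay on MDA-MB-231 cells (Homo sapiens) for inhibition, read by MTT assay, with a stated time of 48 h (a lower number here means a stronger inhibitor, a higher number a weaker inhibitor), compound 2 gives only a limit of the assay, > 50000 nM. Two close relatives were measured in the same way. Compound 1 `O=C1Nc2ccc(Br)cc2/C1=C/c1cccc(OCc2cn(Cc3ccccc3)nn2)c1` has bromo where compound 2 has acetyl, and in this assay compound 1 also reaches only a limit, > 50000 nM. Compound 3 `CC(=O)c1ccc2c(c1)/C(=C\c1cccc(OCc3cn(Cc4ccccc4)nn3)c1)C(=O)N2` has the same atoms and bonds as compound 2 and differs only in the configuration of the drawn double bond; in this assay compound 3 gives a limit as well, > 50000 nM.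

Neither step around compound 2 can be sized: a step that the two limits leave unreadable from compound 1 to compound 2 and a step that the two limits leave unreadable from compound 2 to compound 3 are both unreadable because of the limit of > 50000 nM in this assay, at which 3 of the 3 values shown sit. Compound 4 `COc1ccc(Cc2ccc3c(c2)/C(=C/c2cccc(OCc4cn(Cc5ccccc5)nn4)c2)C(=O)N3)cc1` changes the same position as the first of these steps, with 4-methoxybenzyl in place of acetyl on an aromatic carbon. Within the data shown here, since every value so far sits at the limit, no direction can be read from the measured steps, and the expected step of an at least 1.2-fold lower number from compound 2 to compound 4 (0.09 log units; that floor lies within the scatter) from compound 2 to compound 4 is a guess leaning toward another limit. Compound 4 is therefore expected to give about 40000 nM in this assay, within a range of 5000 nM to 100000 nM.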

Compound 4, half-maximal inhibitory concentration: 20400 nM
Compound 4: the middle estimate sits 2.0-fold (0.29 log units) above what was measured; measured number inside the range.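

In this assay, placing 4-methoxybenzyl on this aromatic carbon gives an at least 2.4-fold lower number from compound 2 to compound 4 (0.38 log units; beyond the scatter) when it replaces acetyl, and an at least 2.4-fold lower number from compound 1 to compound 4 (0.38 log units; beyond the scatter) when it replaces bromo. Among these compounds, compound 4 is thus the first compound here with a readable number, showing that a change at this one position can bring a measurable effect on the cells, and the entering group adds a six-membered aromatic ring of carbon only. Both steps are floors rather than full sizes, so the true gaps could be wider: the limit of > 50000 nM in this assay, at which 3 of the 4 values shown sit.

The compounds shown cannot tell whether the benzyl part or the methoxy group goes with the lower number, and a plain benzyl or a 4-aminobenzyl group at the same carbon would help to separate these. It also remains open whether the configuration of the double bond matters once a number can be read, as the only pair that tests it gives no numbers: the fact that compounds 2 and 3 differ only in the configuration as drawn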